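The source may report more compounds than this note shows. Statements on the series, on what has been measured and on what is new or still open speak of the compounds shown alone.

Compound 1 `CS(=O)(=O)c1ccc(-c2cnc3[nH]cc(-c4nnc(-c5ccncc5)o4)c(=O)c3c2)cc1`: 2.16%
Compound 2 `CS(=O)(=O)c1ccc(-c2cnc3[nH]cc(-c4nnc(-c5ccc(Cl)cc5)o4)c(=O)c3c2)cc1`: 2.15%
Compound 3 `O=c1c(-c2nnc(-c3ccc(Cl)cc3)o2)c[nH]c2ncc(-c3ccccc3)cc12`: 2.15%

In a functional assay on KB cells (Homo sapiens) for inhibition, read by MTT assay, with a stated time of 24 h, tested at 5 uM (a lower number here means less inhibition of growth, a higher number more inhibition of growth at the concentration tested), compound 1 gives 2.16%, the highest of the three numbers, yet within the scatter of both other readings. Compound 4 `Cc1cccc(-c2nnc(-c3c[nH]c4ncc(-c5ccc(S(C)(=O)=O)cc5)cc4c3=O)o2)c1` differs from it in one place: 3-methylphenyl in place of pyridin-4-yl on an aromatic carbon. The step that bears on this is a number 0 percentage points lower from compound 1 to compound 2 (within the scatter), where the same pyridin-4-yl gave way to another aryl group at the same carbon of the shared core; no change at the digits printed from compound 2 to compound 3 (within the scatter) likewise shows the core tolerating a change without moving this assay. Among the compounds with values here, no measured step here exceeds the scatter, so no step beyond it is expected for compound 4. Compound 4 is thus estimated at 2.5%, with a range from 0% to 12%. The expected step is a number 0.3 percentage points higher from compound 1 to compound 4 (within the scatter).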

Compound 4, percent growth inhibition at one concentration: 3.7%
The estimate for compound 4 lay 1.2 percentage points below the measured number; the range from low to high includes it.
By their numbers in this assay, from the lowest: compounds 2, 3, 1 and 4 (each within the scatter of the next).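

In this assay, 3-methylphenyl on this aromatic carbon of the five-membered ring gives a number 1.5 percentage points higher from compound 1 to compound 4 (within the scatter), and in place of 4-chlorophenyl it gives a number 1.6 percentage points higher from compound 2 to compound 4 (within the scatter). Three different aryl groups at this carbon now cannot be told apart, which extends the tolerance seen with the earlier pair to a methyl-bearing ring. Nothing available explains these readings.

Every compound shown carries an aryl group here, so whether an amine or a carboxylic acid at this carbon would move the reading beyond the scatter remains open.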